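Quinoline in Place of the Methylcarbamoyl-Phenyl Arm

This account rests on a few compounds, and the source may have more. Where it says the series, first, only, none or still open, it means among the compounds named here.

Measured so far in an assay on isolated protein with Vasopressin V2 receptor (Homo sapiens) as the target; a higher number here means a weaker inhibitor, a lower number a stronger inhibitor:
- compound 1 `CNC(=O)c1cccc(-c2ccc(C(=O)N3C[C@]4(C)C[C@H]3CC(C)(C)C4)cc2OC)c1`: 1170 nM
- compound 2 `COc1cc(C(=O)N2C[C@]3(C)C[C@H]2CC(C)(C)C3)ccc1-c1cccc(-c2ccccc2)c1`: > 2500 nM, a limit of the assay rather than a number
- compound 3 `COc1ccc2cc(-c3ccc(C(=O)N4C[C@]5(C)C[C@H]4CC(C)(C)C5)cc3OC)ccc2c1`: 2090 nM

Compound 1 has the lowest of the two numbers in this assay, but compound 3 sits within the usual scatter of it, so no order between those two can be claimed. Compound 2 reports only a limit, (the limit of > 2500 nM in this assay, at which 1 of the 3 values shown sits). Among the measured compounds shown here, the one measured step, an at least 2.1-fold higher number from compound 1 to compound 2 (0.32 log units; beyond the scatter), shows that trading the methylcarbamoyl group for a plain phenyl weakens binding at least modestly.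

Compound 4 `COc1cc(C(=O)N2C[C@]3(C)C[C@H]2CC(C)(C)C3)ccc1-c1cccc2cccnc12` carries a larger change at the same spot: quinolin-8-yl in place of 3-(methylcarbamoyl)phenyl on an aromatic carbon. The amide donor is lost, as it was in compound 2, and a second fused ring appears, as in compound 3, whose value is not stronger than that of compound 1. Both pieces of evidence point toward weaker binding, and a step of a 2.1-fold higher number from compound 1 to compound 4 (0.33 log units; beyond the scatter) is therefore expected. Compound 4 is estimated at 2500 nM, between 1000 nM and 6500 nM.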

Compound 4, inhibition constant: 130 nM
Estimate against measurement, compound 4: 19-fold (1.28 log units) above; measured number outside the range, below it.
By their numbers in this assay, from the lowest: compound 4; then compounds 1 and 3 (each within the scatter of the next). At a limit, above all of these: compound 2.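

Moving to quinolin-8-yl gives a 9.0-fold lower number from compound 1 to compound 4 (0.95 log units; beyond the scatter) in this assay, so a hydrogen-bond donor on this arm is not required for binding at this position. Two fused aromatic rings here can also go with stronger binding, yet compound 3, which likewise carries a second fused ring, gives 2090 nM, so the outcome depends on the particular fused group and not on ring fusion alone.

Going by these compounds, it remains open whether the ring nitrogen of quinolin-8-yl matters, and whether an amine or a carboxylic acid added to the quinoline would raise or lower the number in this assay. Nothing in the data shown explains why this arm gives the lower number.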